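The compounds below may be only part of what the source reports. "The series", "measured", "known", "first", "only" and "open" are said of these compounds alone.

Of the compounds shown here, three have been measured in an ADME assay on Vero cells (Chlorocebus sabaeus) for cytotoxicity, read by MTT assay, with a stated time of 72 h; on this read-out higher numbers stand for weaker inhibition and lower numbers for stronger inhibition. Compound 3 `O=[N+]([O-])c1c[nH]c(-c2nnc(-c3ccc[nH]3)o2)c1` gives 227000 nM. Compound 1 `O=[N+]([O-])c1c[nH]c(-c2nnc(-c3ccns3)o2)c1` gives 532000 nM, and the step of a 2.3-fold higher number from compound 3 to compound 1 (0.37 log units; beyond the scatter) goes with the change (1,2-thiazol-5-yl in place of 1H-pyrrol-2-yl on an aromatic carbon). Compound 2 `Cn1cc([N+](=O)[O-])cc1-c1nnc(-c2ccc[nH]2)o1` gives 208000 nM; its core differs from the core of compound 3 by methyl in place of hydrogen on an aromatic nitrogen, and the step of a 1.1-fold higher number from compound 2 to compound 3 (0.04 log units; within the scatter) lies within the scatter. Compound 4 `Cn1cc([N+](=O)[O-])cc1-c1nnc(-c2ccns2)o1` is not yet measured and differs from compound 2 by 1,2-thiazol-5-yl in place of 1H-pyrrol-2-yl on an aromatic carbon. For the measured compounds named here, this is the same kind of change as the one from compound 3 to compound 1, but the place is two ring bonds from the ring atom that bears a group of 9 heavy atoms rather than a group of 8 heavy atoms. For compound 4 a step of a 2.3-fold higher number from compound 2 to compound 4 (0.36 log units; beyond the scatter) is expected in this assay, resting on the step of a 2.3-fold higher number from compound 3 to compound 1 (0.37 log units; beyond the scatter) seen already. Compound 4 is therefore estimated at 480000 nM, expected to fall between 250000 nM and 900000 nM.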

Compound 4, half-maximal inhibitory concentration: 320000 nM
Compound 4: the middle estimate sits 1.5-fold (0.18 log units) above what was measured; low and high end bracket the measured number.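

In this assay, 1,2-thiazol-5-yl in place of 1H-pyrrol-2-yl gives a 1.5-fold higher number from compound 2 to compound 4 (0.19 log units; within the scatter), and this step does not differ from the one on the other core: (the same change on two cores in this assay, a 2.3-fold higher number (0.37 log units; beyond the scatter) from compound 3 to compound 1 and a 1.5-fold higher number (0.19 log units; within the scatter) from compound 2 to compound 4, 1.5-fold (0.18 log units) apart, within the scatter of two such steps). Methyl in place of hydrogen on the aromatic nitrogen, seen as a 1.7-fold lower number from compound 1 to compound 4 (0.22 log units; within the scatter), likewise agrees across the two cores: (the same change on two cores in this assay, a 1.1-fold higher number (0.04 log units; within the scatter) from compound 2 to compound 3 and a 1.7-fold higher number (0.22 log units; within the scatter) from compound 4 to compound 1, 1.5-fold (0.18 log units) apart, within the scatter of two such steps). Both changes thus carry between these two cores within the scatter, but the thiazole step lies beyond the scatter only on the core of compound 3, so a clear shift on both cores is not shown, and two cores cannot speak for the wider series.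

The compounds shown leave open how a phenyl ring or an amine would read in place of 1,2-thiazol-5-yl. They also leave open the effect of a longer chain than methyl on the aromatic nitrogen.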